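The source may report more compounds than this note shows. Statements on the series, on what has been measured and on what is new or still open speak of the compounds shown alone.

In an ADME assay on cells (Fibroblast, Homo sapiens) for cytotoxicity, with a stated time of 48 h (on this read-out lower numbers stand for stronger inhibition and higher numbers for weaker inhibition), compound 2, `O=[N+]([O-])c1ccc(CN2CCC(n3cc(CC(OCc4cc(-c5cccc(Br)c5)no4)c4ccc(Br)cc4)nn3)CC2)cc1`, gives > 25000 nM, which is a limit of the assay and not a measured number. Compound 1, `N#Cc1ccc(-c2cc(COC(Cc3cn(C4CCN(Cc5ccc([N+](=O)[O-])cc5)CC4)nn3)c3ccc(Br)cc3)on2)cc1`, differs from compound 2 in one place. In this assay compound 1 gives > 25000 nM, again a limit. Compound 3, `O=[N+]([O-])c1ccc(CN2CCC(n3cc(CC(OCc4cc(-c5ccccc5Br)no4)c4ccc(Br)cc4)nn3)CC2)cc1`, is the third member of the set. In this assay compound 3 gives > 25000 nM, also a limit. Among the measured steps, a step that the two limits leave unreadable from compound 1 to compound 2, a step that the two limits leave unreadable from compound 2 to compound 3 and a step that the two limits leave unreadable from compound 1 to compound 3 all come out without a readable size, since every value sits at the limit of > 25000 nM in this assay, at which 3 of the 3 values shown sit. Compound 4, `O=[N+]([O-])c1ccc(CN2CCC(n3cc(CC(OCc4cc(-c5ccccc5F)no4)c4ccc(Br)cc4)nn3)CC2)cc1`, has not yet been measured in this assay. The change from compound 2 to compound 4 is 2-fluorophenyl in place of 3-bromophenyl on an aromatic carbon. The measured steps that bear on it, each an exchange of one aryl group for another on the same ring carbon, all stayed at the limit, so no step beyond the scatter can be read from them in either direction. Compound 4 is therefore expected to remain at the limit as well, with an estimated value of 30000 nM and a range from 15000 nM to 100000 nM. The step from compound 2 to compound 4 that this estimate means is expected to be a step that the limit leaves unreadable from compound 2 to compound 4.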

Compound 4, half-maximal inhibitory concentration: > 25000 nM
Compound 4: a limit, no number (the forecaster's own chance of this, stated with the estimate: 85%); the middle value lies beyond the limit too.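

In this assay compound 4 gives > 25000 nM, a limit of the assay and not a number. Its steps from compound 1, compound 2 and compound 3 therefore cannot be read: the limit of > 25000 nM in this assay, at which 4 of the 4 values shown sit.

The compounds shown leave open whether any exchange of aryl group at this place alters the read-out in this assay at all, as none of them gives a measured number.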